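Trifluoromethyl in Place of a Larger Group on an Aromatic Carbon

The source may hold more compounds than are shown below. What is called first, only, known or untested is meant among the compounds shown, and "the series" means these compounds.

Three compounds of one series were measured in a functional assay on VCaP cells (Homo sapiens) for antiproliferative activity, read by propidium iodide staining, with a stated time of 96 h; on this read-out higher numbers stand for weaker inhibition and lower numbers for stronger inhibition. Compound 1 `CC(O)(COc1cccc(S(F)(F)(F)(F)F)c1)C(=O)Nc1ccc(S(F)(F)(F)(F)F)cc1` gives 11400 nM. Compound 2 `CC(O)(COc1cccc(S(F)(F)(F)(F)F)c1)C(=O)Nc1cccc(S(F)(F)(F)(F)F)c1` is built from the same atoms as compound 1 but joined differently, and the difference between the two cores is not broken down here. Compound 2 gives 26700 nM. Compound 3 `CC(O)(COc1cccc(C(F)(F)F)c1)C(=O)Nc1cccc(S(F)(F)(F)(F)F)c1` gives 22500 nM. The step from compound 2 to compound 3 is a group of 4 heavy atoms (1 carbon, 3 fluorine; no ring) in place of a group of 6 heavy atoms (5 fluorine, 1 sulfur; no ring), on an aromatic carbon, and it made a 1.2-fold lower number from compound 2 to compound 3 (0.07 log units; within the scatter).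

Compound 4 `CC(O)(COc1cccc(S(F)(F)(F)(F)F)c1)C(=O)Nc1ccc(C(F)(F)F)cc1` has not yet been measured. It differs from compound 1 by a group of 4 heavy atoms (1 carbon, 3 fluorine; no ring) in place of a group of 6 heavy atoms (5 fluorine, 1 sulfur; no ring), on an aromatic carbon. This is the same kind of change as that from compound 2 to compound 3, but not the same: in compound 3 the entering group sits meta to a large group, whereas in compound 4 it sits para to a large group. Among the compounds with values here, the only measured precedent for the change is the step from compound 2 to compound 3, which stayed within the scatter of this assay, so the expectation for compound 4 rests on a single pair and on a different place around the aromatic carbon.

On that basis compound 4 is expected to show a 1.2-fold lower number from compound 1 to compound 4 (0.08 log units; within the scatter), an estimated 9500 nM, with a likely range from 4000 nM to 25000 nM.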

Compound 4, half-maximal inhibitory concentration: 23800 nM
For compound 4 the middle estimate is 2.5-fold (0.40 log units) below the measured one, within the range that was stated.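

In this assay, trifluoromethyl entering in place of the group of 6 heavy atoms (5 fluorine, 1 sulfur), para to a large group, gave a 2.1-fold higher number from compound 1 to compound 4 (0.32 log units; beyond the scatter), a modest step that lies beyond the scatter and so stands apart from the earlier step, which stayed within it. Even so, the size of the change cannot be said to differ between the two cores, as the gap between the steps does not exceed what two such steps may show by chance: the same change on two cores in this assay, a 1.2-fold lower number (0.07 log units; within the scatter) from compound 2 to compound 3 and a 2.1-fold higher number (0.32 log units; beyond the scatter) from compound 1 to compound 4, 2.5-fold (0.39 log units) apart, within the scatter of two such steps. This shows that the series holds no clear evidence of a core-dependent effect, but it does not show that the change carries over unaltered, since each core offers a single pair and the two pairs also differ in where the group sits.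

Going by these compounds, it remains open how a nitrile or a chlorine atom on the same aromatic carbon would compare with trifluoromethyl and with the larger group in this assay's read-out. Also open, on these data alone, is whether a second pair on either core, for example one with a methoxy group on the other aromatic ring, would bring the two steps closer together or push them further apart.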